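Trading a methyl for a nitro on a triazole ester

This account rests on a few compounds, and the source may have more. Where it says the series, first, only, none or still open, it means among the compounds named here.

Measured compounds:
compound 1 `Cc1nc2ccccc2c(-c2ccccc2)c1C(=O)OCc1cn(-c2ccc(C(C)(C)C)cc2)nn1` — "not determined" (no result reported)
compound 2 `Cc1ccc(Cn2cc(COC(=O)c3c(C)nc4ccccc4c3-c3ccccc3)nn2)cc1` — 41000 nM

Two compounds share the same core and were tested for their effect on mouse macrophage cells. Compound 1 `Cc1nc2ccccc2c(-c2ccccc2)c1C(=O)OCc1cn(-c2ccc(C(C)(C)C)cc2)nn1` carries a substituted phenyl ring on the triazole; for compound 1 the entry reads "not determined" (no result reported). Compound 2 `Cc1ccc(Cn2cc(COC(=O)c3c(C)nc4ccccc4c3-c3ccccc3)nn2)cc1` carries a 4-methylbenzyl group instead, and in an ADME assay on J774.A1 cells (Mus musculus) for cytotoxicity, read by MTT assay, with a stated time of 48 h (on this read-out higher numbers stand for lower toxicity in this test and lower numbers for higher toxicity in this test), compound 2 gives 41000 nM. Among the measured compounds shown here, that is the only number available, so compound 2 stands alone, with nothing to rank it against.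

Compound 3 `Cc1nc2ccccc2c(-c2ccccc2)c1C(=O)OCc1cn(Cc2ccc([N+](=O)[O-])cc2)nn1` is the next compound to be measured. It differs from compound 2 in one place: nitro in place of methyl on an aromatic carbon. For the measured compounds named here, no pair of measured compounds shows what such a change does on this cell line, so there is no step to lean on. With only compound 2 as a reference, the expected step from compound 2 to compound 3 in this assay is a 1.0-fold lower number from compound 2 to compound 3 (0.01 log units; within the scatter), that is, none beyond the usual scatter. Compound 3 is therefore estimated to give 40000 nM in this assay, with a range from 15000 nM to 100000 nM.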

Compound 3, half-maximal cytotoxic concentration: 42000 nM
Compound 3: middle estimate off by 1.1-fold (0.02 log units), on the low side; the measured number falls inside the stated range.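

Among the compounds shown here, replacing 4-methylbenzyl with 4-nitrobenzyl gives a 1.0-fold higher number from compound 2 to compound 3 (0.01 log units; within the scatter) in this assay and so provides the first measured step at this position, on an aromatic carbon para to a large group. Here, a single carbon gives way to a nitro group of three heavy atoms with two hydrogen-bond acceptors, yet the two compounds cannot be told apart on this read-out, so this one swap leaves the cell result effectively unchanged. Nothing measured here bears on why the result came out this way.

This single pair cannot show whether the same position would tolerate every group, and an amine or a carboxylic acid on that ring carbon could give quite a different number. Also open, from the compounds shown here alone, is what a longer chain joining the aromatic ring to the triazole would do, and whether the nitro-for-methyl swap would give the same outcome on a different core or in other cells.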